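Chloro for fluoro on the anilide of compound 3

The source may report more compounds than this note shows. Statements on the series, on what has been measured and on what is new or still open speak of the compounds shown alone.

Compound 3 `O=C(CSc1nncnc1-c1cccc2ccccc12)Nc1ccccc1F` gives 65000 nM in an ADME assay on MT4 cells (Homo sapiens) for cytotoxicity, read by MTT assay (on this read-out lower numbers stand for higher toxicity in this test and higher numbers for lower toxicity in this test), the lowest of the three numbers recorded. Compound 1 `Cc1ccc(NC(=O)CSc2nncnc2-c2cccc3ccccc23)c(Br)c1` gives 166000 nM and compound 2 `Cc1ccccc1NC(=O)CSc1nncnc1-c1cccc2ccccc12` gives 158000 nM; the step of a 2.6-fold lower number from compound 1 to compound 3 (0.41 log units; beyond the scatter) and the step of a 2.4-fold lower number from compound 2 to compound 3 (0.39 log units; beyond the scatter) both reach beyond the scatter, whereas the step of a 1.1-fold lower number from compound 1 to compound 2 (0.02 log units; within the scatter) does not. Compound 4 `O=C(CSc1nncnc1-c1cccc2ccccc12)Nc1ccccc1Cl` carries the change chloro in place of fluoro on an aromatic carbon on an aromatic carbon of a six-membered aromatic ring of carbon only, ortho to a large group. For the measured compounds named here, no measured step exchanges one halogen for another; the two steps that bear on the ring in question, from compound 1 and from compound 2 to compound 3, are modest and both bring a fluoro into that ring. On these data a step of similar modest size at most is expected, in no firm direction, and most probably none beyond the scatter. Compound 4 is therefore estimated at 60000 nM, within a range from 25000 nM to 150000 nM, an expected step of a 1.1-fold lower number from compound 3 to compound 4 (0.03 log units; within the scatter).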

Compound 4, half-maximal cytotoxic concentration: 63000 nM
Estimate against measurement, compound 4: 1.1-fold (0.02 log units) below; measured number inside the range.
By their numbers in this assay, from the lowest: compounds 4 and 3 (each within the scatter of the next); then compounds 2 and 1 (each within the scatter of the next).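

In this assay, this first exchange of one halogen for another, on an aromatic carbon ortho to a large group, does not separate chloro from fluoro: a 1.0-fold lower number from compound 3 to compound 4 (0.01 log units; within the scatter). Compound 4 shows the same modest gaps to the other two compounds as compound 3 does, with a 2.5-fold lower number from compound 2 to compound 4 (0.40 log units; beyond the scatter) and a 2.6-fold lower number from compound 1 to compound 4 (0.42 log units; beyond the scatter), yet the split does not follow halogen as such, and compound 1, which carries a bromo, goes against any such pattern by standing within the scatter of compound 2. Nothing measured here speaks to what lies behind this split.

Going by these compounds, whether a methoxy group or an amine at this place would fall with compounds 3 and 4 or with compounds 1 and 2 remains open. So does the reading of a 2-bromophenyl group without the methyl of compound 1.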